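The source may hold more compounds than are shown below. What is called first, only, known or untested is meant among the compounds shown, and "the series" means these compounds.

In a functional assay on HCT-116 cells (Homo sapiens) for antiproliferative activity; on this read-out lower numbers stand for stronger inhibition and higher numbers for weaker inhibition:

- compound 1 `Cc1c2c(n3c1CCCN[C@@H](C)[C@H](C)Nc1cc-3ccc1C(N)=O)CC(C)(C)CC2=O`: 29 nM
- compound 2 `Cc1c2c(n3c1CCN(C(=O)CN)C[C@@H](C)[C@H](C)Nc1cc-3ccc1C(N)=O)CC(C)(C)CC2=O`: 216 nM
- compound 3 `Cc1c2c(n3c1CCCN(C(=O)CO)[C@@H](C)[C@H](C)Nc1cc-3ccc1C(N)=O)CC(C)(C)CC2=O`: 51 nM

Compound 2 gives the highest number of the three, well clear of both others. Compound 4 `Cc1c2c(n3c1CCN(C(=O)C1(N)CCCC1)C[C@@H](C)[C@H](C)Nc1cc-3ccc1C(N)=O)CC(C)(C)CC2=O` differs from it on a carbonyl carbon: 1-aminocyclopentyl in place of aminomethyl on a carbonyl carbon. Within the data shown here, no measured step makes this swap. The only one available, a 1.8-fold higher number from compound 1 to compound 3 (0.25 log units; within the scatter), puts (hydroxymethyl)carbonyl in place of hydrogen on an amine nitrogen in a ring, so it is only a loose guide. Going by that small step to compound 3, no shift beyond the scatter is expected in this assay, though either direction remains open. The expected step is a 1.3-fold lower number from compound 2 to compound 4 (0.10 log units; within the scatter). Compound 4 is estimated at 170 nM, with an expected range of 55 nM to 520 nM.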

Compound 4, half-maximal inhibitory concentration: 27 nM
Compound 4: middle estimate off by 6.3-fold (0.80 log units), on the high side; measured number below the stated range.
By their numbers in this assay, from the lowest: compounds 4, 1 and 3 (each within the scatter of the next); then compound 2.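

In this assay this carbonyl carbon proves sensitive to what it carries: 1-aminocyclopentyl in place of aminomethyl gives an 8.0-fold lower number from compound 2 to compound 4 (0.90 log units; beyond the scatter) and that step lies beyond the scatter. Hydrogen-bond donor and acceptor counts stay the same, while a five-membered non-aromatic ring of carbon only enters. Nothing measured here explains the size of this step. From the compounds shown here alone, whether the ring itself matters, or only the added carbon atoms, stays open. An open-chain 1-amino-1-methylethyl group or a smaller 1-aminocyclopropyl ring on the same carbonyl carbon would help separate the two.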